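From 4-Methylbenzyl to 3-Phenylpropyl on the Sulfur

The source may report more compounds than this note shows. Statements on the series, on what has been measured and on what is new or still open speak of the compounds shown alone.

Compound 1 `Cc1cc(N2CC[C@@H](C)[C@@H](N(C)c3ncnc4[nH]ccc34)C2)n2nc(SCc3ccc(Cl)cc3)nc2n1` and compound 2 `Cc1ccc(CSc2nc3nc(C)cc(N4CC[C@@H](C)[C@@H](N(C)c5ncnc6[nH]ccc56)C4)n3n2)cc1` share one core and differ in a single place. Among the compounds with values here, in a functional assay on BGC-823 cells (Homo sapiens) for inhibition, read by MTT assay, with a stated time of 72 h (on this read-out higher numbers stand for weaker inhibition and lower numbers for stronger inhibition), compound 1 gives 26300 nM, and compound 2 gives 69500 nM, the higher of the two numbers so far; the step of a 2.6-fold higher number from compound 1 to compound 2 (0.42 log units; beyond the scatter) shows that methyl in place of chloro on an aromatic carbon weakened inhibition modestly. Compound 3 `Cc1cc(N2CC[C@@H](C)[C@@H](N(C)c3ncnc4[nH]ccc34)C2)n2nc(SCCCc3ccccc3)nc2n1` carries a different alteration: phenethyl in place of 4-methylphenyl on a saturated chain carbon bound to a sulfur. Within the data shown here, no measured step concerns a longer saturated chain carrying the ring, so the one recorded step is only a loose guide to how sensitive this assay is to this part of the molecule. The expectation is therefore for no step beyond the scatter, a 1.4-fold lower number from compound 2 to compound 3 (0.14 log units; within the scatter), with wide uncertainty. For compound 3 the estimated value in this assay is 50000 nM, within 18000 nM to 140000 nM.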

Compound 3, half-maximal inhibitory concentration: > 100000 nM
Compound 3: no number, only a limit; the forecaster's own chance of this, stated with the estimate: 20%; middle value at least 2.0-fold (0.30 log units) from the limit.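

In this assay compound 3 gives no number, only a limit: the limit of > 100000 nM in this assay, at which 1 of the 3 values shown sits.

Against the chloro-bearing compound, the record shows an at least 3.8-fold higher number from compound 1 to compound 3 (0.58 log units; beyond the scatter), so inhibition at this position is weakened by more than the chloro-to-methyl change alone had shown. Against the 4-methylbenzyl compound the record reads an at least 1.4-fold higher number from compound 2 to compound 3 (0.15 log units; that floor lies within the scatter), and since this is only a floor, the true size of that step stays undefined.

Compound 3 both lengthens the chain and carries no substituent on its ring, so the compounds shown cannot separate these two changes; a plain benzyl on the sulfur would bear on that. From the compounds shown here alone, how an amine or a carboxylic acid on this ring would read also remains open.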